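The source may report more compounds than this note shows. Statements on the series, on what has been measured and on what is new or still open speak of the compounds shown alone.

Compound 1 `CCC[C@@H]1C(=O)N(C)c2cnc(Nc3ccc(C(=O)NC4CCN(C)CC4)cc3OC)nc2N1C1CCCC1`: 9.9 nM in an assay on isolated protein for inhibition of serine/threonine-protein kinase PLK1 (Homo sapiens), read by Z'-LYTE; a higher number here means a weaker inhibitor, a lower number a stronger inhibitor
Compound 2 `COc1cc(C(=O)NC2CCN(C)CC2)ccc1Nc1ncc2c(n1)N(C1CCCC1)CC(=O)N2C`: 54.1 nM
Compound 3 `COc1cc(C(=O)NC2CCN(C)CC2)ccc1Nc1ncc2c(n1)N(C1CCCC1)[C@H](CC(C)C)C(=O)N2C`: 78 nM

Compound 3 gives the highest number of the three in this assay; its gap to compound 2 lies within the scatter, while the step of a 7.9-fold higher number from compound 1 to compound 3 (0.90 log units; beyond the scatter) lies beyond it. Compound 4 `COc1cc(C(=O)NC2CCN(C)CC2)ccc1Nc1ncc2c(n1)N(C1CCOCC1)[C@H](CC(C)C)C(=O)N2C` differs from compound 3 by a single change: oxan-4-yl in place of cyclopentyl on a nitrogen on an aromatic ring in a ring. Going by the values given here, none of the measured steps touches this position: a 5.5-fold higher number from compound 1 to compound 2 (0.74 log units; beyond the scatter) and a 1.4-fold higher number from compound 2 to compound 3 (0.16 log units; within the scatter) concern a group on a saturated ring carbon, and a 7.9-fold higher number from compound 1 to compound 3 (0.90 log units; beyond the scatter) a saturated chain carbon. The measured steps therefore give no direct guide, and no change beyond the scatter is expected, a 1.3-fold higher number from compound 3 to compound 4 (0.11 log units; within the scatter). Compound 4 is estimated at 100 nM, with a range from 40 nM to 250 nM.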

Compound 4, half-maximal inhibitory concentration: 322 nM
For compound 4 the middle estimate is 3.2-fold (0.51 log units) below the measured one, outside the stated range (above it).
By their numbers in this assay, from the lowest: compound 1; then compounds 2 and 3 (each within the scatter of the next); then compound 4.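

Going by these compounds alone, changing the group on this nitrogen does shift the result in this assay, with oxan-4-yl in place of cyclopentyl giving a 4.1-fold higher number from compound 3 to compound 4 (0.62 log units; beyond the scatter), whereas all the earlier compounds carried cyclopentyl here. This single change adds a ring oxygen, a hydrogen-bond acceptor and a sixth ring atom together, so the step cannot separate their contributions. Nothing available explains the weaker inhibition.

Cyclohexyl, an all-carbon six-membered ring, would help separate ring size from the oxygen. Also open, on these data alone, is whether the step would hold with propyl instead of isobutyl on the saturated ring carbon.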